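The compounds below may be only part of what the source reports. "The series", "measured", "known", "first", "only" and "open" are said of these compounds alone.

Compound 1, `O=C(Nc1nc(-c2ccccc2)nc2c1nnn2Cc1ccccc1)c1ccc(Cl)cc1`, gives 108 nM in an assay (strain Wistar) for displacement of a labelled ligand from adenosine receptor A1 (Rattus norvegicus), read by scintillation counting; on this read-out lower numbers stand for stronger inhibition and higher numbers for weaker inhibition.
Compound 2, `O=C(Nc1nc(-c2ccccc2)nc2c1nnn2Cc1ccccc1)c1cccc(F)c1`, gives 22 nM.
Compound 3, `Nc1nc(-c2ccccc2)nc2c1nnn2Cc1ccccc1`, gives 5.6 nM.

Compound 3 thus has the lowest number of the three, with compound 2 a modest distance away and compound 1 much further. Compound 4, `O=C(Nc1nc(-c2ccccc2)nc2c1nnn2Cc1ccccc1)c1ccccc1F`, differs from compound 3 in one place: (2-fluorophenyl)carbonyl in place of hydrogen on a nitrogen on an aromatic ring. Going by the values given here, two measured steps bear on this change, both the same acylation read in reverse: a 19-fold lower number from compound 1 to compound 3 (1.29 log units; beyond the scatter) and a 3.9-fold lower number from compound 2 to compound 3 (0.59 log units; beyond the scatter). Each acyl group raised the number relative to the free amine, and a 4.9-fold lower number from compound 1 to compound 2 (0.69 log units; beyond the scatter) shows that the substituent on the benzoyl ring sets the size of that rise. No fluorine placed as in compound 4 has been measured, so the direction looks clear but the size is uncertain. Compound 4 is therefore expected to give 40 nM, in the range 12 nM to 130 nM, a step of a 7.1-fold higher number from compound 3 to compound 4 (0.85 log units; beyond the scatter).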

Compound 4, inhibition constant: 40 nM
Estimate against measurement, compound 4: no gap at the digits printed, within the range that was stated.
By their numbers in this assay, from the lowest: compound 3; then compounds 2 and 4 (each within the scatter of the next); then compound 1.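

In this assay a third acyl group also gives a number above that of the free amine, with a 7.1-fold higher number from compound 3 to compound 4 (0.85 log units; beyond the scatter), so all three amides shown lie above compound 3. The step between the 3-fluorophenyl and 2-fluorophenyl amides is a 1.8-fold higher number from compound 2 to compound 4 (0.26 log units; within the scatter), so these two fluorine placements cannot be told apart here. The 4-chlorophenyl amide stays apart, with a 2.7-fold lower number from compound 1 to compound 4 (0.43 log units; beyond the scatter).

Nothing shown accounts for these steps. As far as these compounds go, whether an acetyl group on that nitrogen, or a methoxy group on the phenyl ring of the amide, would follow these amides remains open.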